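From 3-methylphenyl to 4-methoxyphenyl: a step yet unmeasured

The source may hold more compounds than are shown below. What is called first, only, known or untested is meant among the compounds shown, and "the series" means these compounds.

Compound 1 (`C/C(=C\CC/C(C)=C/CC[C@@H]1[C@@]2(C)CCC(=O)C(C)(C)[C@H]2CC[C@@]1(C)O)CC/C=C(\C)C(=O)OCc1cn(-c2ccc(F)cc2)nn1`) gives > 150000 nM as a limit
Compound 2 (`C/C(=C\CC/C(C)=C/CC[C@@H]1[C@@]2(C)CCC(=O)C(C)(C)[C@H]2CC[C@@]1(C)O)CC/C=C(\C)C(=O)OCc1cn(-c2ccc(F)c(Cl)c2)nn1`) gives > 150000 nM as a limit
Compound 3 (`C/C(=C\CC/C(C)=C/CC[C@@H]1[C@@]2(C)CCC(=O)C(C)(C)[C@H]2CC[C@@]1(C)O)CC/C=C(\C)C(=O)OCc1cn(-c2cccc(C)c2)nn1`) gives 137000 nM as a number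

All three values come from a functional assay on DU-145 cells (Homo sapiens) for antiproliferative activity, read by MTT assay, with a stated time of 48 h; a lower number here means a stronger inhibitor, a higher number a weaker inhibitor. For the measured compounds named here, compound 3 holds the only true number in the set (137000 nM). The other two compounds stand at a limit (the limit of > 150000 nM in this assay, at which 2 of the 3 values shown sit). Compound 4 (`COc1ccc(-n2cc(COC(=O)/C(C)=C/CC/C(C)=C/CC/C(C)=C/CC[C@@H]3[C@@]4(C)CCC(=O)C(C)(C)[C@H]4CC[C@@]3(C)O)nn2)cc1`) carries 4-methoxyphenyl in place of 3-methylphenyl on an aromatic nitrogen. Two measured steps change this same group (an at least 1.0-fold lower number from compound 1 to compound 3 (0.03 log units; that floor lies within the scatter) and an at least 1.0-fold lower number from compound 2 to compound 3 (0.03 log units; that floor lies within the scatter)). Both give only a floor, so neither shows a real effect of the swap. No step beyond the scatter is therefore expected in this assay. The expected step is small (a 1.0-fold higher number from compound 3 to compound 4 (0.01 log units; within the scatter)). Compound 4 is estimated at 140000 nM, with an expected range from 90000 nM to 220000 nM.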

Compound 4, half-maximal inhibitory concentration: 135000 nM
Estimate against measurement, compound 4: 1.0-fold (0.02 log units) above; the range from low to high includes it.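

In this assay, for the compounds shown here, this change on the aromatic nitrogen gives the first step between two true numbers: a 1.0-fold lower number from compound 3 to compound 4 (0.01 log units; within the scatter). Against the two compounds at the limit only floors can be read, an at least 1.1-fold lower number from compound 2 to compound 4 (0.04 log units; that floor lies within the scatter) and an at least 1.1-fold lower number from compound 1 to compound 4 (0.04 log units; that floor lies within the scatter), and neither shows a real effect of the swap. Compound 1 and compound 2 remain at a limit: the limit of > 150000 nM in this assay, at which 2 of the 4 values shown sit.

Going by these compounds, what an amine or a carboxylic acid in place of the methoxy would give in this assay stays open. So does whether any change to the shared core would move the number beyond the scatter.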